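Sulfonyl aryl change on the shared core

This account rests on a few compounds, and the source may have more. Where it says the series, first, only, none or still open, it means among the compounds named here.

Three compounds of the series have numbers in a functional assay on CHO.K1 cells for antagonist activity at prostaglandin D2 receptor 2 (Homo sapiens), read by GTPgammaS binding, with a stated time of 1 h; a higher number here means a weaker inhibitor, a lower number a stronger inhibitor. Compound 1 `Cc1c(Cc2ccc(C(=O)O)cc2S(=O)(=O)c2ccccc2)c2c(n1CC(=O)O)CCNC2=O` gives 19 nM. Within the data shown here, compound 2 `COC(=O)c1ccc(Cc2c3c(n(CC(=O)O)c2C)CCNC3=O)c(S(=O)(=O)c2ccccc2)c1` gives 11 nM; the step of a 1.7-fold lower number from compound 1 to compound 2 (0.24 log units; within the scatter) is the only single-point change measured so far and sits on an oxygen next to a carbonyl group, away from the sulfonyl. Compound 3 `Cc1c(Cc2ccccc2S(=O)(=O)c2ccccc2F)c2c(n1CC(=O)O)CCNC2=O` gives 3.6 nM, the lowest of the three numbers, with compound 2 nearest and compound 1 furthest, both gaps beyond the scatter. Compound 4 `Cc1c(Cc2ccccc2S(=O)(=O)c2ccc(OC(F)(F)F)cc2)c2c(n1CC(=O)O)CCNC2=O` has not been measured. It differs from compound 3 by 4-(trifluoromethoxy)phenyl in place of 2-fluorophenyl on a sulfonyl sulfur. Among the measured compounds shown here, no measured step bears on an exchange of the aryl group on the sulfonyl sulfur; the single step known lies within the scatter and concerns another part of the molecule. The expectation for compound 4 is therefore a step of a 1.4-fold higher number from compound 3 to compound 4 (0.14 log units; within the scatter), with no direction that the data would support. Compound 4 is estimated at 5 nM, with a range from 1.5 nM to 18 nM.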

Compound 4, half-maximal inhibitory concentration: 6.6 nM
Compound 4: the middle estimate sits 1.3-fold (0.12 log units) below what was measured; the measured number falls inside the stated range.
By their numbers in this assay, from the lowest: compounds 3, 4, 2 and 1 (each within the scatter of the next, the first and the last beyond it).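

In this assay, the first exchange read at the sulfonyl sulfur, 4-(trifluoromethoxy)phenyl in place of 2-fluorophenyl, gives a step within the scatter (a 1.8-fold higher number from compound 3 to compound 4 (0.26 log units; within the scatter)). The entering group has 11 heavy atoms against 7 and 1 hydrogen-bond acceptor against 0, so this position accepts a larger aryl group here without a step beyond the scatter. Nothing measured on the compounds accounts for this result.

Among these compounds, the single step removes the 2-fluoro pattern and brings in the 4-(trifluoromethoxy) pattern together, so the two parts of the exchange cannot be told apart. Open too, as far as these compounds go, is what a sulfonyl sulfur carrying an aminophenyl group, a carboxyphenyl group or a simple methyl group in place of the aryl ring would give on this core.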